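This account rests on a few compounds, and the source may have more. Where it says the series, first, only, none or still open, it means among the compounds named here.

Compound 1 `CCCS(=O)(=O)Nc1ccc(F)c(C(=O)c2n[nH]c3ncc(-c4ccccc4O)cc23)c1F` is one of three compounds tested in an assay for binding affinity to dual specificity mitogen-activated protein kinase kinase 4 (Homo sapiens), read by KINOMEscan, tested at 100 nM; a lower number here means a stronger effect, a higher number a weaker effect of the compound at the concentration tested. There compound 1 gives 9%, the second highest of the three numbers. Compound 2 `CCCS(=O)(=O)Nc1ccc(F)c(C(=O)c2n[nH]c3ncc(-c4ccc(N(C)C)cc4)cc23)c1F` gives 2.5%, and compound 3 `CCCS(=O)(=O)Nc1ccc(F)c(C(=O)c2n[nH]c3ncc(-c4ccc(Cl)cc4Cl)cc23)c1F` gives 22%. The change a number 6.5 percentage points lower from compound 1 to compound 2 (within the scatter) stays within the scatter, while the change a number 13 percentage points higher from compound 1 to compound 3 (beyond the scatter) is a modest rise, as is a number 19.5 percentage points higher from compound 2 to compound 3 (beyond the scatter).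

The unmeasured compound 4 `CCCS(=O)(=O)Nc1ccc(F)c(C(=O)c2n[nH]c3ncc(-c4ccc(C(C)C)cc4)cc23)c1F` differs from compound 1 in one place: 4-isopropylphenyl in place of 2-hydroxyphenyl on an aromatic carbon. The two steps that start from compound 1 bear on this: one partner without the hydroxyl, compound 2, stays within the scatter, and the other, compound 3, moves modestly higher. Going by the values given here, no other step is known. The step from compound 1 to compound 4 in this assay is therefore expected to be a number 1 percentage points higher from compound 1 to compound 4 (within the scatter), small and not clearly beyond the scatter. Compound 4 is estimated at 10%, with a likely range from 3% to 25%.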

Compound 4, a percentage reported as activity, at one concentration (the size of the read-out at that concentration, not a potency): 17%
For compound 4 the middle estimate is 7 percentage points below the measured one, within the range that was stated.
By their numbers in this assay, from the lowest: compounds 2, 1, 4 and 3 (each within the scatter of the next, the first and the last beyond it).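

In this assay, replacing the 2-hydroxyphenyl with 4-isopropylphenyl gives a number 8 percentage points higher from compound 1 to compound 4 (within the scatter), so a phenyl group without a hydroxyl and with no hydrogen-bond donor or acceptor can stay level with compound 1 at this position. The result for compound 4 also lies close to the dichlorinated partner, with a number 5 percentage points lower from compound 3 to compound 4 (within the scatter), whereas exchanging only the group at the 4-position of the phenyl gives a number 14.5 percentage points higher from compound 2 to compound 4 (beyond the scatter), showing that this single exchange is enough to move the read-out beyond the scatter. No available evidence explains these steps.

Still open, going by these compounds, is how an unsubstituted phenyl, a 4-methoxyphenyl or a 4-carboxyphenyl would read at this position. A primary amine at the 4-position would help show whether the dimethylamino result extends to other amines.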